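The compounds below may be only part of what the source reports. "The series", "measured", "known", "first", "only" and "open" are said of these compounds alone.

Two compounds have so far been measured in an assay on isolated protein for displacement of a labelled ligand from Apoptosis regulator Bcl-2 (Homo sapiens), read by fluorescence polarization; on this read-out lower numbers stand for stronger inhibition and higher numbers for weaker inhibition:

Compound 1, `COC1(Cc2cccc(Cl)c2)CCN(c2ccc(C(=O)NS(=O)(=O)c3ccc(N[C@H](CCN(C)C)CSc4ccccc4)c([N+](=O)[O-])c3)cc2)CC1`, gives 1.8 nM.
Compound 2, `COC1(Cc2ccccc2C)CCN(c2ccc(C(=O)NS(=O)(=O)c3ccc(N[C@H](CCN(C)C)CSc4ccccc4)c([N+](=O)[O-])c3)cc2)CC1`, gives 1.4 nM.

Going by the values given here, compound 2 holds the lower of the two numbers, but the only step between them, a 1.3-fold lower number from compound 1 to compound 2 (0.11 log units; within the scatter), lies within the scatter, so the two cannot be told apart on these data.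

Compound 3, `COc1ccccc1CC1(OC)CCN(c2ccc(C(=O)NS(=O)(=O)c3ccc(N[C@H](CCN(C)C)CSc4ccccc4)c([N+](=O)[O-])c3)cc2)CC1`, has not yet been measured. It differs from compound 2 by methoxy in place of methyl on an aromatic carbon. Among the compounds with values here, the single measured step that bears on this change is a 1.3-fold lower number from compound 1 to compound 2 (0.11 log units; within the scatter), in which exchanging one substituted phenyl for another at the same place left the number within the scatter. Within the data shown here, no measured step exchanges methyl for methoxy on that ring, so nothing beyond that one comparison can be drawn on. On this basis the step of a 1.1-fold higher number from compound 2 to compound 3 (0.06 log units; within the scatter) is expected to be small, with no direction that exceeds the scatter. Compound 3 is accordingly estimated at 1.6 nM in this assay, with a range from 0.7 nM to 4 nM.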

Compound 3, inhibition constant: 1.6 nM
The estimate for compound 3 equals the measured number at the digits printed; low and high end bracket the measured number.
By their numbers in this assay, from the lowest: compounds 2, 3 and 1 (each within the scatter of the next).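

In this assay, going by these compounds alone, the exchange of methyl for methoxy on an aromatic carbon ortho to a large group, which brings in an oxygen and a hydrogen-bond acceptor that methyl lacks, gives a 1.1-fold higher number from compound 2 to compound 3 (0.06 log units; within the scatter) and so adds a first direct comparison at this place to the earlier exchange of one substituted phenyl for another. The exchange of 3-chlorophenyl for 2-methoxyphenyl gives a 1.1-fold lower number from compound 1 to compound 3 (0.05 log units; within the scatter) and thus also cannot be read as a change, which leaves chloro, methyl and methoxy phenyl forms all within the scatter of one another in these three compounds. No measurement or other information is given here that could account for this outcome.

On these data alone, whether an amine, a carboxylic acid or a longer chain on this ring would likewise leave the number within the scatter stays open, as does the result for a phenyl ring carrying no substituent at all. As far as these compounds go, all three compounds also share the rest of their structure, so it remains open whether these exchanges would behave the same way on a different core.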